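The source may report more compounds than this note shows. Statements on the series, on what has been measured and on what is new or still open speak of the compounds shown alone.

Measured compounds:
Compound 1 `O=c1[nH]cc(S(=O)(=O)Nc2ccccc2-c2cn(-c3ccc(F)cc3)nn2)c(=O)[nH]1` — in a functional assay on SGC-7901 cells (Homo sapiens) for antiproliferative activity, read by MTT assay, with a stated time of 24 h (on this read-out lower numbers stand for stronger inhibition and higher numbers for weaker inhibition), compound 1 gives > 20000 nM, which is a limit of the assay and not a number.
Compound 2 `O=c1[nH]cc(S(=O)(=O)Nc2cccc(-c3cn(-c4ccc(F)cc4)nn3)c2)c(=O)[nH]1` — compound 2 gives > 20000 nM, likewise a limit and not a number.
Compound 3 `Cc1ccc(-n2cc(-c3ccc(NS(=O)(=O)c4c[nH]c(=O)[nH]c4=O)cc3)nn2)cc1` — compound 3 gives 8350 nM.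

Among the compounds with values here, compound 3 therefore stands alone as the only member of the set with a numeric reading; the other two sit at the limit of > 20000 nM in this assay, at which 2 of the 3 values shown sit. Within the data shown here, no two measured compounds differ in a single place, so no step size can be read off from the measured set, and the comparison of compound 3 with compound 1 and compound 2 shows only a number against two limits.

Compound 4 `O=c1[nH]cc(S(=O)(=O)Nc2ccc(-c3cn(-c4cccc(Cl)c4)nn3)cc2)c(=O)[nH]1` remains to be measured. It differs from compound 3 by 3-chlorophenyl in place of 4-methylphenyl on an aromatic nitrogen. Nothing in the measured set speaks to an exchange at this position, so the expected step from compound 3 to compound 4 is none beyond the usual scatter, a 1.1-fold higher number from compound 3 to compound 4 (0.03 log units; within the scatter). Compound 4 is accordingly estimated at 9000 nM in this assay, with a range from 3500 nM to 22000 nM, and a real chance that only a limit is returned.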

Compound 4, half-maximal inhibitory concentration: 2460 nM
For compound 4 the middle estimate is 3.7-fold (0.56 log units) above the measured one; the whole stated range lies above it.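

In this assay, within the data shown here, placing 3-chlorophenyl instead of 4-methylphenyl on the aromatic nitrogen gives a 3.4-fold lower number from compound 3 to compound 4 (0.53 log units; beyond the scatter) and provides the first readable step in the set, showing that the group at this position can shift the reading beyond the scatter, if only modestly. Both groups have 7 heavy atoms and neither has a hydrogen-bond donor or acceptor, so the step appears with those counts unchanged. Compound 1 and compound 2 cannot extend this reading, since each differs from compound 4 in more than one place and each gives only a limit: the limit of > 20000 nM in this assay, at which 2 of the 4 values shown sit.

This single step changes both the substituent and its place on the phenyl ring, so the effect of chlorine in place of methyl cannot be separated from the effect of position without a pair such as 3-methylphenyl and 4-chlorophenyl. Also open, from the compounds shown here alone, is how this position responds to a phenyl ring bearing an amine or a carboxylic acid, or to a longer alkyl chain in place of the aryl group.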